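The source may report more compounds than this note shows. Statements on the series, on what has been measured and on what is new or still open speak of the compounds shown alone.

Compound 3 `Cc1ccc(C(F)F)cc1` holds the highest number of the three measured in a physicochemical assay for lipophilicity, read by spectrophotometry, using the shake flask method, measured as octanol-water partition (a lower number here means a more polar compound, a higher number a more lipophilic compound), where compound 3 gives 2.94. Its nearest neighbour is compound 2 `FC(F)c1ccccc1`, which in this assay gives 2.4; the step is a number 0.54 log units higher from compound 2 to compound 3 (beyond the scatter), with methyl in place of hydrogen on an aromatic carbon. Furthest off is compound 1 `N#Cc1ccc(C(F)F)cc1`, which in this assay gives 1.75; the steps are a number 1.19 log units higher from compound 1 to compound 3 (beyond the scatter) and a number 0.65 log units higher from compound 1 to compound 2 (beyond the scatter).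

Compound 4 `COc1ccc(C(F)F)cc1` is not yet measured. It differs from compound 3 by methoxy in place of methyl on an aromatic carbon. For the measured compounds named here, no measured step involves a methoxy group, so only the methyl step bears on it: the rise from compound 2 to compound 3 shows what the methyl that now leaves contributed. Compound 4 is therefore expected to fall below compound 3 by a modest step, estimated as a number 0.54 log units lower from compound 3 to compound 4 (beyond the scatter). In this assay compound 4 is expected to give about 2.4, within a range from 2.1 to 2.7.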

Compound 4, partition coefficient: 2.61
The estimate for compound 4 lay 0.21 log units below the measured number; low and high end bracket the measured number.
By their numbers in this assay, from the lowest: compound 1; then compounds 2 and 4 (each within the scatter of the next); then compound 3.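

In this assay, methoxy on an aromatic carbon para to a difluoromethyl group does not read like methyl, which lacks its oxygen: the measured change is a number 0.33 log units lower from compound 3 to compound 4 (beyond the scatter) and so lies beyond the scatter. Set against hydrogen at this place, methoxy gives a number 0.21 log units higher from compound 2 to compound 4 (within the scatter) and leaves compounds 2 and 4 indistinguishable here, whereas methyl in place of hydrogen moved the number beyond the scatter. Against cyano, methoxy gives a number 0.86 log units higher from compound 1 to compound 4 (beyond the scatter) and so joins hydrogen and methyl in standing clear of the nitrile compound.

Nothing given here accounts for these differences. Still open, from the compounds shown here alone, is whether an ethoxy group, a hydroxyl or an amine at this place would stay level with hydrogen and methoxy or come closer to methyl, and whether the same order holds on another core.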